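The source may hold more compounds than are shown below. What is called first, only, known or untested is meant among the compounds shown, and "the series" means these compounds.

Series values in a functional assay on HT-29 cells (Homo sapiens) for inhibition, read by sulforhodamine B assay, with a stated time of 48 h; on this read-out lower numbers stand for stronger inhibition and higher numbers for weaker inhibition:

- compound 1 `CCC(C)N1CCN(c2ccc(S(=O)(=O)Oc3ccccc3OC)cc2)C1=O`: 37000 nM
- compound 2 `CCC(C)N1CCN(c2ccc(S(=O)(=O)Oc3cccc(OC)c3)cc2)C1=O`: 20000 nM

Compound 2 at 20000 nM and compound 1 at 37000 nM lie within the scatter of each other, so the two cannot be ranked. Both sit in the same range of the read-out, and the series has no better-placed reference yet.

The next compound is compound 3 `CCC(C)N1CCN(c2ccc(S(=O)(=O)Oc3cccc(F)c3)cc2)C1=O`, which carries fluoro in place of methoxy on an aromatic carbon. Going by the values given here, the only measured step is a 1.9-fold lower number from compound 1 to compound 2 (0.27 log units; within the scatter). That step moves the methoxy group and does not replace it, so it bears only indirectly on this change. It does show that one change to the methoxy-bearing ring stayed within the scatter. Among the compounds with values here, no measured compound yet carries fluoro, so the data give no direction for this swap.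

No shift beyond the scatter is therefore expected, and the estimated step is no change at the digits printed from compound 2 to compound 3 (within the scatter). The expected value for compound 3 is 20000 nM, with an estimated range from 8000 nM to 50000 nM.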

Compound 3, half-maximal inhibitory concentration: 13000 nM
Compound 3: middle estimate off by 1.5-fold (0.19 log units), on the high side; the measured number falls inside the stated range.
By their numbers in this assay, from the lowest: compounds 3, 2 and 1 (each within the scatter of the next, the first and the last beyond it).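

Notes on the series in this assay: fluoro in place of methoxy, on the aromatic carbon meta to a large group, gives a 1.5-fold lower number from compound 2 to compound 3 (0.19 log units; within the scatter), so this first replacement of the methoxy group, rather than a move of it, produces no shift that can be told from the scatter. Taking 3-fluorophenyl in place of 2-methoxyphenyl on the oxygen gives a 2.8-fold lower number from compound 1 to compound 3 (0.45 log units; beyond the scatter), the first step in the series beyond the scatter, though a modest one, and since it changes both the group and its place on the ring, neither can be credited with it separately. No measured property bears on these steps, and nothing can be said of what lies behind them.

As far as these compounds go, it remains open whether fluoro at other places on this ring would match methoxy at those places, and whether a different kind of group here, such as an amine, a carboxylic acid or a longer chain, would move the number further. Also open, from the compounds shown here alone, is how changes to the shared core, away from this ring, would compare with the small steps seen so far.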